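Nitro for methoxy on the benzoyl ring of a chalcone

A few compounds are considered here, and "the series" means these few. Any claim that something is new, unique, unknown or untested is made for them only; others in the source may bear on it.

Measured in an ADME assay on MSTO-211H cells (Homo sapiens) for inhibition, read by trypan blue exclusion, with a stated time of 72 h; on this read-out higher numbers stand for weaker inhibition of growth and lower numbers for stronger inhibition of growth:
compound 1, `O=C(/C=C/c1ccccc1)c1cccc([N+](=O)[O-])c1`, gives 10300 nM;
compound 2, `COc1cccc(C(=O)/C=C/c2ccccc2)c1`, gives 14800 nM;
compound 3, `COc1ccccc1C(=O)/C=C/c1ccccc1`, gives 9500 nM.

All three values lie within the scatter of one another, so no order among them is claimed. Compound 2 and compound 3 have the same atoms joined differently; the difference between the two cores is not broken down here. From compound 2 to compound 1 the change is nitro in place of methoxy on an aromatic carbon, and it made a 1.4-fold lower number from compound 2 to compound 1 (0.16 log units; within the scatter).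

Compound 4, `O=C(/C=C/c1ccccc1)c1ccccc1[N+](=O)[O-]`, has not been measured. It arises from compound 3 by nitro in place of methoxy on an aromatic carbon, the same kind of change, but where the place in compound 1 is meta to a large group, in compound 4 it is ortho to a large group. Among the compounds with values here, with only one prior example, and that within the scatter, the expected step is a small one: a 1.2-fold lower number from compound 3 to compound 4 (0.07 log units; within the scatter) is estimated, resting on compound 1 and a 1.4-fold lower number from compound 2 to compound 1 (0.16 log units; within the scatter). Compound 4 is therefore expected to give about 8000 nM, with a range of 3500 nM to 18000 nM.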

Compound 4, concentration for 50% growth inhibition: 9800 nM
Estimate against measurement, compound 4: 1.2-fold (0.09 log units) below; low and high end bracket the measured number.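

In this assay, nitro in place of methoxy on an aromatic carbon, here ortho to a large group, gave a 1.0-fold higher number from compound 3 to compound 4 (0.01 log units; within the scatter). Set beside the earlier case, the two steps do not differ: the same change on two cores in this assay, a 1.4-fold lower number (0.16 log units; within the scatter) from compound 2 to compound 1 and a 1.0-fold higher number (0.01 log units; within the scatter) from compound 3 to compound 4, 1.5-fold (0.17 log units) apart, within the scatter of two such steps. Within the data shown here, the change therefore carries from one core to the other without any difference that can be read, but since neither step lies beyond the scatter, this shows only that the swap left the number within the scatter on both cores; it does not show that nitro and methoxy are interchangeable in general, and two pairs set no rule for the series.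

The compounds shown leave open whether another group in the same places, such as an amine, a carboxylic acid or a longer alkoxy chain, would give a step beyond the scatter. They also leave open whether the nitro for methoxy change holds at any other place on this ring or on the other aromatic ring.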